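The compounds below may be only part of what the source reports. "The series", "measured", "known", "first", "only" and "open" are said of these compounds alone.

Measured so far:
Compound 1, `CCCOc1ccc(-c2nn3c(NC4CCCC4)nccc3c2-c2ccnc(NC3CCCC3)n2)cc1`: in an ADME assay on Vero cells (Chlorocebus sabaeus) for cytotoxicity (a higher number here means that more compound is tolerated, a lower number that less compound is tolerated), compound 1 gives > 20000 nM, an assay limit rather than a number.
Compound 2, `CC(C)COc1ccc(-c2nn3c(NC4CCCC4)nccc3c2-c2ccnc(NC3CCCC3)n2)cc1`: in this assay compound 2 gives > 40000 nM, likewise an assay limit.

Compound 2 therefore stands only at a limit in this assay, and no number places it within the set. Both values shown are limits: the limit of > 20000 nM in this assay, at which 1 of the 2 values shown sits, and (the limit of > 40000 nM in this assay, at which 1 of the 2 values shown sits). For the measured compounds named here, the one measured step, a step that the two limits leave unreadable from compound 1 to compound 2, is left unreadable by those two limits, so its size is not known.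

Compound 3, `c1cc(-c2c(-c3ccc(OCC4CC4)cc3)nn3c(NC4CCCC4)nccc23)nc(NC2CCCC2)n1`, differs from compound 2 by cyclopropyl in place of isopropyl on a saturated chain carbon bound to an oxygen on an aromatic ring. Going by the values given here, no measured step bears on this change; the only step in the set is unreadable and concerns a different change. What the data do show is that compound 1 and compound 2 both sit at limits in this assay, and the change to compound 3 is a small exchange of one saturated carbon fragment for another. For compound 3 a step that the limit leaves unreadable from compound 2 to compound 3 is expected, that is, none beyond the scatter, with the read-out most likely again reported only as a limit. Compound 3 is estimated at 50000 nM, within a range from 20000 nM to 150000 nM.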

Compound 3, half-maximal cytotoxic concentration: > 40000 nM
Compound 3: no number, only a limit (the forecaster's own chance of this, stated with the estimate: 80%); the middle value does not contradict the limit.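

For the compounds shown here, no step among compound 1, compound 2 and compound 3 can be read in this assay, as all three values are assay limits rather than numbers. The compounds shown leave open where the half-maximal cytotoxic concentration of any of them lies, and whether replacing isobutyl with cyclopropylmethyl changes it at all.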